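The compounds below may be only part of what the source reports. "The series", "measured", "known", "first", "only" and "open" are said of these compounds alone.

Among the measured compounds shown here, compound 1 `CC1(c2ccccc2)CC(=O)C(C2CC(c3ccc(-c4ccc(Br)cc4)cc3)Cc3ccccc32)=C(O)O1` is the only member of this small set with a numeric reading: in a functional assay on XF498 cells (Homo sapiens) for inhibition, with a stated time of 72 h (a higher number here means a weaker inhibitor, a lower number a stronger inhibitor), compound 1 gives 1360 nM. Compound 2 `CC1(c2ccccc2)CC(=O)C(C2CC(c3ccc(OCc4ccc(C(F)(F)F)cc4)cc3)Cc3ccccc32)=C(O)O1` carries a (4-(trifluoromethyl)benzyl)oxy group in place of the 4-bromophenyl group of compound 1. In this assay compound 2 gives > 10000 nM, which is a limit of the assay and not a number. Compound 3 `CCC1(c2ccccc2)CC(=O)C(C2CC(c3ccc(-c4ccc(Br)cc4)cc3)Cc3ccccc32)=C(O)O1` instead carries a methyl in place of hydrogen on a saturated chain carbon bound to a saturated ring carbon. In this assay compound 3 gives > 10000 nM, again a limit of the assay. Both steps from compound 1 are therefore losses: an at least 7.3-fold higher number from compound 1 to compound 2 (0.86 log units; beyond the scatter) and an at least 7.3-fold higher number from compound 1 to compound 3 (0.86 log units; beyond the scatter). Compound 3 thus stands at the limit of > 10000 nM in this assay, at which 2 of the 3 values shown sit, with no number of its own to anchor it.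

Compound 4 `CCC1(c2ccccc2)CC(=O)C(C2CC(c3ccc(OCc4ccc(C(F)(F)F)cc4)cc3)Cc3ccccc32)=C(O)O1` combines the two changes. The difference from compound 3 is (4-(trifluoromethyl)benzyl)oxy in place of 4-bromophenyl on an aromatic carbon. The step that bears on it is an at least 7.3-fold higher number from compound 1 to compound 2 (0.86 log units; beyond the scatter), a loss. Given that loss and the fact that compound 3 already stands at the limit, the estimated step is a step that the limit leaves unreadable from compound 3 to compound 4. Compound 4 is therefore expected to give 40000 nM in this assay, within a range of 10000 nM to 200000 nM.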

Compound 4, half-maximal inhibitory concentration: > 10000 nM
Compound 4: only a limit was reported (the forecaster's own chance of this, stated with the estimate: 92%); the middle value lies beyond the limit too.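

In this assay compound 4 gives > 10000 nM as a limit of the assay and not a number. Its steps from compound 2 and from compound 3 therefore cannot be read, since all three compounds sit at the same limit: the limit of > 10000 nM in this assay, at which 3 of the 4 values shown sit. The compounds shown leave open how far compound 2, compound 3 and compound 4 actually differ from one another.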